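The source may report more compounds than this note shows. Statements on the series, on what has been measured and on what is new or still open speak of the compounds shown alone.

Measured so far:
Compound 1 `COc1cc2c(cc1OC)C(CC(N)=O)CC2` — in a functional assay on the whole organism (strain Wistar) for inhibition, with Rattus norvegicus as the target, read by paw edema, with stated times of 60 min and 2 h, at a dose of 100 mg/kg by the oral route (a lower number here means less inhibition, a higher number more inhibition at the dose given (going by the name of the read-out)), compound 1 gives 31%.
Compound 2 `CNC(=O)CC1CCc2cc(OC)c(OC)cc21` — in this assay compound 2 gives 30%.

Compound 2 stands within the scatter of compound 1; the two numbers cannot be told apart on this read-out. Among the measured compounds shown here, the only step measured so far, a number 1 percentage points lower from compound 1 to compound 2 (within the scatter), is a methyl in place of hydrogen on an amide-type nitrogen and produced no change beyond the scatter.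

The next compound, compound 3 `COc1cc2c(cc1OC)C(CC(=O)N(C)C)CC2`, is not yet measured. It differs from compound 2 by methyl in place of hydrogen on an amide-type nitrogen. For the measured compounds named here, the measured step from compound 1 to compound 2 is the one comparison that bears on it, being the same kind of change at the same amide nitrogen, and that step was within the scatter. On that basis no step beyond the scatter is expected in this assay for compound 3: the expected step is no change at the digits printed from compound 2 to compound 3 (within the scatter).

The estimate for compound 3 in this assay is therefore 30%, with a range from 15% to 45%.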

Compound 3, a percentage reported as inhibition, in the whole organism at one dose (the size of the read-out at that dose, not a potency): 36%
Compound 3: middle estimate off by 6 percentage points, on the low side, and the stated range covers the measured number.
By their numbers in this assay, from the lowest: compounds 2, 1 and 3 (each within the scatter of the next).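

In this assay, the second methyl on the amide-type nitrogen gives a number 6 percentage points higher from compound 2 to compound 3 (within the scatter), so this change has now been read twice at this nitrogen, each time without a step beyond the scatter. Read as one change, dimethylamino in place of amino on a carbonyl carbon gives a number 5 percentage points higher from compound 1 to compound 3 (within the scatter), so even replacing both amide hydrogens with methyl leaves the paw edema read-out at this single oral dose within the scatter, and this amide nitrogen shows no measurable dependence on the choice among hydrogen and methyl in these three compounds. No measurement at hand speaks to any cause for these small differences.

The compounds shown cover only hydrogen and methyl on this nitrogen, with the same (methylcarbamoyl)methyl-type side chain on the shared core, so it remains open whether an ethyl or benzyl group on the nitrogen would produce a step beyond the scatter. Also open, from the compounds shown here alone, is whether a carboxylic acid in place of the amide, or a longer chain between the core and the carbonyl, would move the number beyond the scatter.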